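A few compounds are considered here, and "the series" means these few. Any claim that something is new, unique, unknown or untested is made for them only; others in the source may bear on it.

Measured so far in an ADME assay on Akata cells (Homo sapiens) for cytotoxicity, with a stated time of 7 days; on this read-out higher numbers stand for lower toxicity in this test and lower numbers for higher toxicity in this test:

Compound 1, `CC(C)CSc1nc(N)nc2c1ncn2/C=C1/CC1(CO)CO`: > 20000 nM
Compound 2, `CN(C)c1nc(N)nc2c1ncn2/C=C1/CC1(CO)CO`: > 24000 nM
Compound 3, `CCCCCCCCSc1nc(N)nc2c1ncn2/C=C1/CC1(CO)CO`: > 20000 nM

Compound 2 stands only at a limit of this assay, and the two other values are limits as well. Compound 1 sits at the limit of > 20000 nM in this assay, at which 2 of the 3 values shown sit, together with compound 3. Compound 2 sits at the limit of > 24000 nM in this assay, at which 1 of the 3 values shown sits. None of the three gives a number, so the steps between them cannot be read: a step that the two limits leave unreadable from compound 1 to compound 2, a step that the two limits leave unreadable from compound 2 to compound 3, and a step that the two limits leave unreadable from compound 1 to compound 3. What the three compounds share is that every measured change at the aromatic carbon, whether to isobutylsulfanyl, dimethylamino or octylsulfanyl, left the read-out beyond the upper limit of this assay.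

Compound 4, `CCCCCOc1nc(N)nc2c1ncn2/C=C1/CC1(CO)CO`, carries a change at the same place: pentyloxy in place of dimethylamino on an aromatic carbon. Among the compounds with values here, both steps that touch this position from compound 2 were unreadable, so they give no direction for the change to pentyloxy and no size of step. Compound 4 is therefore expected to behave like the three measured compounds and to give no number below the limit, with the step that the limit leaves unreadable from compound 2 to compound 4 expected not to be readable. The estimate for compound 4 in this assay is 30000 nM, between 15000 nM and 80000 nM.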

Compound 4, half-maximal cytotoxic concentration: > 20000 nM
Compound 4: a limit, no number; the forecaster's own chance of this, stated with the estimate: 85%; the middle value does not contradict the limit.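

In this assay compound 4 gives > 20000 nM as a limit and not a number, and none of the steps to compound 4 from compound 1, compound 2 or compound 3 can be read. The compounds shown leave open whether any group at this aromatic carbon would give a number within the range of this test, and how large any step between these groups is.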